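Benzyl for Methyl on the Selenium of Compound 1

A few compounds are considered here, and "the series" means these few. Any claim that something is new, unique, unknown or untested is made for them only; others in the source may bear on it.

The measured compounds:
compound 1, `C[Se]/C(=N\C(=O)c1cc2ccccc2s1)NC(=O)c1cc2ccccc2s1`, 65600 nM
compound 2, `CS/C(=N\C(=O)c1ccco1)NC(=O)c1ccco1`, > 100000 nM
compound 3, `CS/C(=N\C(=O)c1cc(-c2ccccc2)nc2ccccc12)NC(=O)c1cc(-c2ccccc2)nc2ccccc12`, > 100000 nM

In a functional assay on PC-3 cells (Homo sapiens) for cytotoxicity, read by MTT assay, with a stated time of 72 h (a lower number here means a stronger inhibitor of growth, a higher number a weaker inhibitor of growth), compound 1 gives 65600 nM. For compound 2 the result is a limit of the assay, > 100000 nM. For compound 3 the result is likewise a limit, > 100000 nM. Going by the values given here, compound 1 therefore stands as the only actual number among the three, the other two sitting at the limit of > 100000 nM in this assay, at which 2 of the 3 values shown sit.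

Compound 4 `O=C(/N=C(/NC(=O)c1cc2ccccc2s1)[Se]Cc1ccccc1)c1cc2ccccc2s1` differs from compound 1 by phenyl in place of hydrogen on a saturated chain carbon bound to a selenium atom. Among the compounds with values here, no measured pair shows what such a change does here. The step of a 1.6-fold lower number from compound 1 to compound 4 (0.21 log units; within the scatter) is therefore expected to be modest, at most a little beyond the scatter, and toward stronger inhibition if anything. Compound 4 is estimated at 40000 nM, with a range from 15000 nM to 100000 nM.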

Compound 4, concentration for total growth inhibition: 58400 nM
Compound 4: middle estimate off by 1.5-fold (0.16 log units), on the low side; measured number inside the range.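

In this assay, going by these compounds alone, the change from methyl to benzyl gives a 1.1-fold lower number from compound 1 to compound 4 (0.05 log units; within the scatter), the first reading at this position, so a phenyl is accepted here with no shift beyond the scatter. Compound 4, like compound 1, gives an actual number and does not join the values at the limit: the limit of > 100000 nM in this assay, at which 2 of the 4 values shown sit.

On these data alone, whether an amine, a carboxylic acid or a longer chain on the saturated chain carbon bound to the selenium atom would behave the same stays open. Compound 2 and compound 3 differ from compound 1 in more than one place, so the part played by selenium itself cannot be read.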